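This account rests on a few compounds, and the source may have more. Where it says the series, first, only, none or still open, it means among the compounds named here.

Measured compounds:
Compound 1 `CN(C)CCn1cnnc1-c1cc(Oc2ccc(NC(=O)Nc3ccc(Cl)c(C(F)(F)F)c3)cc2F)ccn1`: in a functional assay on NCI-H460 cells (Homo sapiens) for antiproliferative activity, read by MTT assay, with a stated time of 72 h (a lower number here means a stronger inhibitor, a higher number a weaker inhibitor), compound 1 gives 1150 nM.
Compound 2 `CCN(CC)CCn1cnnc1-c1cc(Oc2ccc(NC(=O)Nc3ccc(Cl)c(C(F)(F)F)c3)cc2F)ccn1`: in this assay compound 2 gives 850 nM.
Compound 3 `CCN(CC)CCn1cnnc1-c1cc(Oc2ccc(NC(=O)Nc3ccc(F)c(Cl)c3)cc2F)ccn1`: in this assay compound 3 gives 7390 nM.

Compound 2 has the lowest number of the three, but its nearest neighbour is compound 1, and the step of a 1.4-fold lower number from compound 1 to compound 2 (0.13 log units; within the scatter) is within the scatter, so the two cannot be ordered. The furthest neighbour is compound 3, reached by an 8.7-fold higher number from compound 2 to compound 3 (0.94 log units; beyond the scatter), a change on the amide-type nitrogen, which is a different part of the molecule from the one considered next.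

Compound 4 `CN(C)CCCn1cnnc1-c1cc(Oc2ccc(NC(=O)Nc3ccc(Cl)c(C(F)(F)F)c3)cc2F)ccn1` differs from compound 2 as follows: (dimethylamino)methyl in place of diethylamino on a saturated chain carbon, two bonds along the chain from an aromatic nitrogen. Going by the values given here, the only measured step that bears on this position is a 1.4-fold lower number from compound 1 to compound 2 (0.13 log units; within the scatter), which exchanged the amine substituents and stayed within the scatter. Among the compounds with values here, no measured step changes the chain length, so the step of an 8.7-fold higher number from compound 2 to compound 3 (0.94 log units; beyond the scatter) offers no guidance here. On that basis the expected step is a 1.2-fold higher number from compound 2 to compound 4 (0.07 log units; within the scatter), that is, none beyond the scatter. The estimate for compound 4 in this assay is 1000 nM, with a range from 400 nM to 2500 nM.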

Compound 4, half-maximal inhibitory concentration: 1680 nM
Estimate against measurement, compound 4: 1.7-fold (0.23 log units) below, within the range that was stated.
By their numbers in this assay, from the lowest: compounds 2, 1 and 4 (each within the scatter of the next); then compound 3.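

In this assay, the 3-(dimethylamino)propyl chain of compound 4 extends the test of this position from the amine substituents to the chain itself, and the exchange for 2-(diethylamino)ethyl gives a 2.0-fold higher number from compound 2 to compound 4 (0.30 log units; within the scatter). Compared with compound 1, which also carries dimethylamino, the change in the chain gives a 1.5-fold higher number from compound 1 to compound 4 (0.16 log units; within the scatter), so neither change separates compound 4 from its neighbours and, among compounds 1, 2 and 4, these chain and amine changes do not register beyond the scatter. No measurement bears on why these values stay so close.

The compounds shown leave open whether a longer chain such as 4-(dimethylamino)butyl or a ring amine such as morpholine would move the number beyond the scatter. Also open, as far as these compounds go, is whether a carboxylic acid in place of the amine would do so.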